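A few compounds are considered here, and "the series" means these few. Any claim that something is new, unique, unknown or untested is made for them only; others in the source may bear on it.

compound 1 `N[C@@H](CCC(=O)OC[C@H]1O[C@@H](n2cc(F)c(=O)[nH]c2=O)C[C@@H]1OC(=O)CC[C@H](N)C(=O)O)C(=O)O`: 0.238 h
compound 2 `N[C@@H](CC(=O)OC[C@H]1O[C@@H](n2cc(F)c(=O)[nH]c2=O)C[C@@H]1O)C(=O)O`: 0.223 h
compound 3 `CC(C)[C@H](N)C(=O)OC[C@H]1O[C@@H](n2cc(F)c(=O)[nH]c2=O)C[C@@H]1O`: 0.273 h

In an ADME assay on tissue (ZR-75-1 cells, Homo sapiens) for pharmacokinetics (a lower number here means that the compound disappears faster, a higher number that the compound lasts longer), compound 3 gives 0.273 h. All three values lie within the usual scatter of each other, so compound 3 does not stand apart from the others.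

The next compound, compound 4 `CC(C)[C@H](N)C(=O)OC[C@H]1O[C@@H](n2cc(F)c(=O)[nH]c2=O)C[C@@H]1OC(=O)[C@@H](N)C(C)C`, keeps all of compound 3 and adds one group: (1-amino-2-methylpropyl)carbonyl in place of hydrogen on an oxygen on a saturated carbon. In words, (1-amino-2-methylpropyl)carbonyl takes the place of hydrogen on an oxygen on a saturated carbon, turning a hydroxy into ((1-amino-2-methylpropyl)carbonyl)oxy.

Within the data shown here, no measured pair shows this exact change, so the evidence is indirect. Among the measured compounds shown here, the one measured step, a 1.2-fold higher number from compound 2 to compound 3 (0.09 log units; within the scatter), exchanged one group for another on a carbonyl carbon and stayed within the scatter. Compound 1 also carries a group on that oxygen, and at 0.238 h it lies within the scatter of the two compounds that keep the hydroxy.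

On this basis, no step beyond the scatter is expected in this assay, and no direction can be called. The expected step is a 1.1-fold lower number from compound 3 to compound 4 (0.04 log units; within the scatter). Compound 4 is estimated at 0.25 h, with an expected range of 0.14 h to 0.45 h.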

Compound 4, half-life: 0.112 h
For compound 4 the middle estimate is 2.2-fold (0.35 log units) above the measured one; measured number below the stated range.
By their numbers in this assay, from the lowest: compounds 4, 2, 1 and 3 (each within the scatter of the next, the first and the last beyond it).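

In this assay, turning the hydroxy on this oxygen into ((1-amino-2-methylpropyl)carbonyl)oxy gives a 2.4-fold lower number from compound 3 to compound 4 (0.39 log units; beyond the scatter) and thus a modest but real shift towards faster disappearance. This shows that a change at this oxygen on a saturated carbon can move the half-life beyond the scatter, something the earlier exchange on a carbonyl carbon did not do, with a 1.2-fold higher number from compound 2 to compound 3 (0.09 log units; within the scatter) as its step. No measurement among the data shown accounts for this shift.

Going by these compounds, it remains open whether the shift depends on the amine and branched chain of this particular group or would follow from any carbonyl-linked group on this oxygen, and a plain acetyl group or a methyl ether there would help to separate those possibilities. This single step also cannot show whether the same addition would have a similar effect on a core carrying a different group on its other ester.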